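This account rests on a few compounds, and the source may have more. Where it says the series, first, only, none or still open, it means among the compounds named here.

Measured so far:
compound 1 `CS(=O)(=O)N1CC(CCl)c2ccc(N)cc21`: 158000 nM
compound 2 `CN(C)c1ccc2c(c1)N(S(C)(=O)=O)CC2CCl`: 72000 nM

For the measured compounds named here, in a functional assay on CHO-AA8 cells (Cricetulus griseus) for cytotoxicity, with a stated time of 4 h (on this read-out lower numbers stand for stronger inhibition and higher numbers for weaker inhibition), compound 2 stands at the lower of the two numbers, compound 1 at the higher; the single measured step is a 2.2-fold lower number from compound 1 to compound 2 (0.34 log units; beyond the scatter), a modest one, beyond the scatter.

Compound 3 `CS(=O)(=O)N1CC(CCl)c2ccc(S)cc21` is not yet measured. The change is sulfanyl in place of dimethylamino on an aromatic carbon. Going by the values given here, no measured step exchanges dimethylamino for sulfanyl. Among the compounds with values here, the only step available, a 2.2-fold lower number from compound 1 to compound 2 (0.34 log units; beyond the scatter), concerns dimethylamino against amino, and the group that entered there is the group that leaves here, so it bears on this step only indirectly. Loss of dimethylamino is therefore taken to undo roughly that step, giving back a number near that of compound 1 in this assay, with wide uncertainty in both directions.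

Compound 3 is expected near 120000 nM, within 40000 nM to 400000 nM. This estimate corresponds to an expected step of a 1.7-fold higher number from compound 2 to compound 3 (0.22 log units; within the scatter), upward, at the edge of the scatter.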

Compound 3, half-maximal inhibitory concentration: > 200000 nM
Compound 3 was reported as a limit; the forecaster's own chance of this, stated with the estimate: 15%; middle value at least 1.6-fold (0.22 log units) away from the limit.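

In this assay compound 3 stands at > 200000 nM, a limit of the assay and not a number: the limit of > 200000 nM in this assay, at which 1 of the 3 values shown sits. Even so, sulfanyl in place of dimethylamino on this aromatic carbon gives an at least 2.7-fold higher number from compound 2 to compound 3 (0.44 log units; beyond the scatter), so the exchange at this position has a readable direction, and the low end of the series so far belongs to dimethylamino, as a 2.2-fold lower number from compound 1 to compound 2 (0.34 log units; beyond the scatter) had suggested from the amino side alone. Sulfanyl in place of amino reads an at least 1.2-fold higher number from compound 1 to compound 3 (0.10 log units; that floor lies within the scatter), so no order between these two groups can be drawn.

Where compound 3 truly lies past its limit stays open. So does how a methoxy group, a carboxylic acid or a longer dialkylamino chain on this aromatic carbon would read against dimethylamino.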